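Fluoro for Nitro in Benzothiazole Enaminone Analogues

The compounds below may be only part of what the source reports. "The series", "measured", "known", "first", "only" and "open" are said of these compounds alone.

The measured compounds:
compound 1, `COc1ccc(C(=O)/C=C\Nc2ccc(-c3nc4cc(OC)c(OC)c(OC)c4s3)cc2C)cc1F`, 1200 nM
compound 2, `COc1ccc(C(=O)/C=C\Nc2ccc(-c3nc4cc(OC)c(OC)c(OC)c4s3)cc2C)cc1[N+](=O)[O-]`, 13400 nM
compound 3, `COc1ccc2nc(-c3ccc(N/C=C\C(=O)c4ccc(OC)c([N+](=O)[O-])c4)cc3)sc2c1`, 17600 nM

All three were tested in a functional assay on HeLa cells (Homo sapiens) for antiproliferative activity, read by sulforhodamine B assay, with a stated time of 48 h; on this read-out lower numbers stand for stronger inhibition and higher numbers for weaker inhibition. Compound 2 and compound 1 share one core and differ only by fluoro in place of nitro on an aromatic carbon; that change gave an 11-fold lower number from compound 2 to compound 1 (1.05 log units; beyond the scatter). Compound 3 carries a different core; the difference between the core of compound 3 and the core of compound 2 is not broken down here. In this assay compound 3 gives 17600 nM, and compound 2 gives 13400 nM, so these two lie within the scatter of each other.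

Compound 4, `COc1ccc2nc(-c3ccc(N/C=C\C(=O)c4ccc(OC)c(F)c4)cc3)sc2c1`, has not yet been measured. It differs from compound 3 by fluoro in place of nitro on an aromatic carbon, the same change as from compound 2 to compound 1, at the same place. If the change acts alike on the second core, a step of about the size seen from compound 2 to compound 1 is expected; the estimate here is a step of a 9.8-fold lower number from compound 3 to compound 4 (0.99 log units; beyond the scatter), resting on compound 3 at 17600 nM. Compound 4 is therefore expected to give about 1800 nM, between 700 nM and 4500 nM.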

Compound 4, half-maximal inhibitory concentration: 500 nM
Compound 4: the middle estimate sits 3.6-fold (0.56 log units) above what was measured, and the stated range ends above it.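

In this assay, fluoro in place of nitro again gave stronger inhibition, with a 35-fold lower number from compound 3 to compound 4 (1.55 log units; beyond the scatter) on the second core, so the direction of the change held on both cores. The size of the step did not carry over exactly, and the gap between the two steps is larger than repeat measurements would be expected to produce: the same change on two cores in this assay, an 11-fold lower number (1.05 log units; beyond the scatter) from compound 2 to compound 1 and a 35-fold lower number (1.55 log units; beyond the scatter) from compound 3 to compound 4, 3.2-fold (0.50 log units) apart, beyond the scatter of two such steps. This shows that the benefit of the change can depend on the core, but two pairs of compounds cannot show which difference between the cores sets the size of the step, or what the change would do on a third core.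

The compounds shown leave open whether another group in place of the nitro, such as chloro, a nitrile or an amine, would give a result closer to that of fluoro or of nitro. They also leave open what happens when the methoxy group ortho to the changed position is replaced, for example by a hydroxyl group or a longer chain.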